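The source may hold more compounds than are shown below. What is called first, only, known or untested is meant among the compounds shown, and "the series" means these compounds.

Among the compounds with values here, compound 2, `Clc1ccc(-c2cn3ccnc3c(-c3ccc4ncn(C5CCCCC5)c4c3)n2)cc1`, gives the higher of the two numbers so far recorded: in a functional assay on T47D cells (Homo sapiens) for inhibition, read by sulforhodamine B assay, with a stated time of 48 h, tested at 10 uM (a higher number here means more inhibition at the concentration tested (going by the name of the read-out), a lower number less inhibition), compound 2 gives 27.6%, and compound 1, `COc1ccc(-c2cn3ccnc3c(-c3ccc4ncn(C5CCCCC5)c4c3)n2)cc1`, gives -8.6%. Within the data shown here, the one measured step, a number 36.2 percentage points higher from compound 1 to compound 2 (beyond the scatter), replaces a methoxy with a chloro on an aromatic carbon and so speaks to the group on that phenyl ring, not to a move of the substituent to another position. Compound 3, `Fc1ccccc1-c1cn2ccnc2c(-c2ccc3ncn(C4CCCCC4)c3c2)n1`, differs from compound 2 by 2-fluorophenyl in place of 4-chlorophenyl on an aromatic carbon. Among the measured compounds shown here, no measured step exchanges one halogen for another, and none shifts a substituent from one ring position to another, so that step offers only an indirect guide. Compound 3 is therefore expected to land somewhat below compound 2, with the step of a number 15.6 percentage points lower from compound 2 to compound 3 (beyond the scatter) in this assay expected to be modest and uncertain in direction. For compound 3 the estimate in this assay is 12%, within a range from -12% to 36%.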

Compound 3, a percentage reported as inhibition, at one concentration (the size of the read-out at that concentration, not a potency): 77.2%
Estimate against measurement, compound 3: 65.2 percentage points below, outside the stated range (above it).
By their numbers in this assay, from the lowest: compound 1; then compound 2; then compound 3.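

Replacing 4-chlorophenyl with 2-fluorophenyl on this aromatic carbon gives a number 49.6 percentage points higher from compound 2 to compound 3 (beyond the scatter) in this assay, which shows that the aryl group here can move the inhibition at the concentration tested well beyond the level of compound 2. Against the methoxy-bearing compound the change is a number 85.8 percentage points higher from compound 1 to compound 3 (beyond the scatter), and compound 3 stands highest of the three in this assay. Nothing available explains why this group gives so much more inhibition. The change alters the halogen and its place on the phenyl ring in a single step, so the share of each in the gain cannot be separated. From the compounds shown here alone, how an amine or a carboxylic acid on this phenyl ring would fare in this assay also remains open.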